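Swapping the Hydroxyphenyl Group of Compound 3

The source may report more compounds than this note shows. Statements on the series, on what has been measured and on what is new or still open speak of the compounds shown alone.

In a functional assay on SK-MEL-2 cells (Homo sapiens) for inhibition (on this read-out lower numbers stand for stronger inhibition of growth and higher numbers for weaker inhibition of growth), compound 3 `O=C(/C=C/c1cccc(O)c1)c1cccc(-n2cc(-c3ccc(Cl)cc3)[nH]c2=O)c1` gives 2070 nM. That lies within the scatter of compound 1 `COc1cc(/C=C/C(=O)c2cccc(-n3cc(-c4ccc(Cl)cc4)[nH]c3=O)c2)cc(OC)c1OC` at 3440 nM, while compound 2 `O=C(/C=C/c1cccc(O)c1)c1cccc(-n2cc(-c3ccccc3)[nH]c2=O)c1` gives a clearly higher 8260 nM. Compound 4 `COc1cc(/C=C/C(=O)c2cccc(-n3cc(-c4ccc(Cl)cc4)[nH]c3=O)c2)ccc1O` differs from compound 3 by one change: 4-hydroxy-3-methoxyphenyl in place of 3-hydroxyphenyl on a double-bonded chain carbon bound to a double-bonded chain carbon. Going by the values given here, the only measured step, a 4.0-fold lower number from compound 2 to compound 3 (0.60 log units; beyond the scatter), is a modest one for chloro in place of hydrogen on an aromatic carbon, a different change that compound 4 does not reverse. No measurement tests the new group directly, so a step beyond the scatter is not expected, and the estimated change is a 1.3-fold higher number from compound 3 to compound 4 (0.10 log units; within the scatter). Compound 4 is expected near 2600 nM, with an estimated range of 1100 nM to 6000 nM.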

Compound 4, concentration for 50% growth inhibition: 3660 nM
Estimate against measurement, compound 4: 1.4-fold (0.15 log units) below; measured number inside the range.
By their numbers in this assay, from the lowest: compounds 3, 1 and 4 (each within the scatter of the next); then compound 2.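

In this assay, placing 4-hydroxy-3-methoxyphenyl where 3-hydroxyphenyl stood gives a 1.8-fold higher number from compound 3 to compound 4 (0.25 log units; within the scatter). This is the first step shown at this position, and it suggests that, at least for this pair, a group of 9 heavy atoms can replace one of 7 without a change that stands out from the scatter. No measurement available here bears on the reason for this result.

From the compounds shown here alone, since the new group differs in both its hydroxy and its methoxy substituents, the effect of each alone remains unknown. Going by these compounds, it also remains open how an amine or a carboxylic acid on this phenyl ring would behave.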